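The source may hold more compounds than are shown below. What is called first, only, known or untested is meant among the compounds shown, and "the series" means these compounds.

Three compounds built on one shared core have numbers in a functional assay on HT-29 cells (Homo sapiens) for inhibition, with a stated time of 72 h; on this read-out higher numbers stand for weaker inhibition and lower numbers for stronger inhibition. Compound 1 `COc1ccc(S(=O)(=O)N2CCc3cccc(-c4ccc(N)cc4)c32)cc1`, which carries a 4-aminophenyl group, gives 301 nM. Compound 2 `COc1ccc(S(=O)(=O)N2CCc3cccc(-c4ccc(F)c(F)c4)c32)cc1`, which carries a 3,4-difluorophenyl group, gives 57 nM, the lowest number of the three. Compound 3 `COc1ccc(S(=O)(=O)N2CCc3cccc(-c4cc(OC)c(OC)c(OC)c4)c32)cc1` gives 5100 nM, so the group on this ring clearly matters in this series.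

Compound 4 `COc1ccc(S(=O)(=O)N2CCc3cccc(-c4cccc(F)c4)c32)cc1` has not been measured yet. It differs from compound 2 in one place: hydrogen in place of fluoro on an aromatic carbon. Here hydrogen stands in place of fluoro on an aromatic carbon, which turns 3,4-difluorophenyl into 3-fluorophenyl.

For the measured compounds named here, only one measured step involves a single swap on this ring, and it bears on the question only loosely. That step, a 5.3-fold lower number from compound 1 to compound 2 (0.72 log units; beyond the scatter), exchanged a whole set of groups, so for the loss of one fluoro a smaller step is expected in this assay. The direction is uncertain, though a slightly higher number seems more likely than a lower one, and the change may well stay within the scatter. The estimated move is a 1.8-fold higher number from compound 2 to compound 4 (0.24 log units; within the scatter). For compound 4 the estimated value is 100 nM, with an expected range from 35 nM to 300 nM.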

Compound 4, half-maximal inhibitory concentration: 119 nM
Beside the measured number, compound 4's estimate is 1.2-fold (0.08 log units) below it, within the range that was stated.
By their numbers in this assay, from the lowest: compound 2; then compound 4; then compound 1; then compound 3.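

Taking away the fluoro that sits ortho to a fluoro group and para to a large group gives a 2.1-fold higher number from compound 2 to compound 4 (0.32 log units; beyond the scatter) in this assay, which shows that this one atom makes a modest but real difference on the read-out. Compound 4 also falls between the two earlier compounds, with a 2.5-fold lower number from compound 1 to compound 4 (0.40 log units; beyond the scatter), so 3-fluorophenyl still gives a lower number than 4-aminophenyl and the second fluoro is not needed for at least part of that advantage. No measured property of these groups is available to explain either step.

The compounds shown leave open how the plain phenyl group, which carries no fluoro at all, would compare, and so whether the remaining fluoro of compound 4 contributes anything of its own. They also leave open whether a chloro group or a nitrile at the place this fluoro left would restore the lower number of compound 2, or whether that number is specific to fluoro.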